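This account rests on a few compounds, and the source may have more. Where it says the series, first, only, none or still open, it means among the compounds named here.

For the measured compounds named here, compound 2 `COc1cc(OC)c(-c2coc3cc(OCc4ccc(C#N)cc4)ccc3c2=O)cc1OC` gives the only number so far in a functional assay on HCT-116 cells (Homo sapiens) for antiproliferative activity, read by MTT assay, with a stated time of 24 h (on this read-out higher numbers stand for weaker inhibition and lower numbers for stronger inhibition), namely 4220 nM. Compound 1 `COc1cc(OC)c(-c2coc3cc(OCc4ccc([N+](=O)[O-])cc4)ccc3c2=O)cc1OC` reaches only the limit of > 10000 nM in this assay. Going by the values given here, the one measured step, an at least 2.3-fold lower number from compound 1 to compound 2 (0.37 log units; beyond the scatter), starts from that limit, so its true size is only partly known (the limit of > 10000 nM in this assay, at which 1 of the 2 values shown sits). Compound 3 `COc1cc(OC)c(-c2coc3cc(OCc4cccc(C(F)(F)F)c4)ccc3c2=O)cc1OC` differs from compound 2 in one place: 3-(trifluoromethyl)phenyl in place of 4-cyanophenyl on a saturated chain carbon bound to an oxygen on an aromatic ring. Among the compounds with values here, no measured step covers this change, so the step expected from compound 2 to compound 3 is a 1.2-fold higher number from compound 2 to compound 3 (0.07 log units; within the scatter), nothing clearly beyond the scatter. Compound 3 is therefore estimated at 5000 nM, between 1800 nM and 14000 nM.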

Compound 3, half-maximal inhibitory concentration: 3400 nM
Compound 3: middle estimate off by 1.5-fold (0.17 log units), on the high side; the range from low to high includes it.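

Swapping 4-cyanophenyl for 3-(trifluoromethyl)phenyl at this position gives a 1.2-fold lower number from compound 2 to compound 3 (0.09 log units; within the scatter), so in this assay the nitrile is not essential: a group with no hydrogen-bond acceptor serves equally well. Replacing 4-nitrophenyl with the same group gives an at least 2.9-fold lower number from compound 1 to compound 3 (0.46 log units; beyond the scatter), a step whose true size stays only partly known, as it starts from a limit: the limit of > 10000 nM in this assay, at which 1 of the 3 values shown sits.

Compound 2 and compound 3 differ both in the group on the ring and in where it sits, so these two changes cannot be told apart. From the compounds shown here alone, whether an amine or a carboxylic acid on this ring would give a clearly lower number remains open.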